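The source may hold more compounds than are shown below. What is called first, only, known or untested is meant among the compounds shown, and "the series" means these compounds.

Of the compounds shown here, three have been tested in a functional assay on the whole organism (blood) with Rattus norvegicus as the target, with stated times of 24 h and 1 h, at a dose of 5 mg/kg by the intraperitoneal route; a lower number here means a weaker effect, a higher number a stronger effect of the compound at the dose given. Compound 1 `COc1ccc(C(=O)NCCC2CCN(S(=O)(=O)NC(=O)NC[C@@H]3C[C@@H]4C=C[C@@H]3C4)CC2)cn1` gives 11%, compound 2 `O=C(NC1CCCCC1)NS(=O)(=O)N1CCC(CCNC(=O)c2ccnc3ccccc23)CC1` gives 16%, and compound 3 `COc1ncccc1C(=O)NCCC1CCN(S(=O)(=O)NC(=O)NC[C@H]2C[C@@H]3C=C[C@@H]2C3)CC1` gives 20%. Compound 3 holds the highest of the three numbers, yet its gaps to compound 2 and to compound 1 both lie within the usual scatter, so no order among the three can be claimed. Compound 4 `COc1ncccc1C(=O)NCCC1CCN(S(=O)(=O)NC(=O)NCC2CCCCO2)CC1` differs from compound 3 in one place: a group of 6 heavy atoms (5 carbon, 1 oxygen; one six-membered non-aromatic ring with 1 hetero atom) in place of a group of 7 heavy atoms (7 carbon; 2 five-membered non-aromatic rings of carbon only), on a saturated chain carbon bound to an amide-type nitrogen. Going by the values given here, none of the measured compounds shows what such a change does in this assay, and all three values sit close together, so a step of a number 2 percentage points lower from compound 3 to compound 4 (within the scatter) is expected, which is none beyond the scatter. Compound 4 is estimated at 18%, within a range from 8% to 30%.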

Compound 4, a percentage reported as activity, at one dose (the size of the read-out at that dose, not a potency): 12%
The estimate for compound 4 lay 6 percentage points above the measured number, and the stated range covers the measured number.
By their numbers in this assay, from the lowest: compounds 1, 4, 2 and 3 (each within the scatter of the next).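

Putting oxan-2-yl in place of the group of two five-membered carbon rings, on a saturated chain carbon bound to an amide-type nitrogen, gives a number 8 percentage points lower from compound 3 to compound 4 (within the scatter) in this assay. Going by these compounds alone, this is the first single-place comparison in the set, and at this dose the read-out does not separate the two groups. No available evidence bears on this result.

On these data alone, it remains open whether an amine, a carboxylic acid or a longer chain at this place would give a step beyond the scatter.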